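This account rests on a few compounds, and the source may have more. Where it says the series, first, only, none or still open, it means among the compounds named here.

Of the compounds shown here, three have been measured in a functional assay on BaF3 cells (Mus musculus) for antiproliferative activity, with a stated time of 48 h (a higher number here means a weaker inhibitor, a lower number a stronger inhibitor), and they sit at the weak end of the scale. In that test compound 1 `CC(=O)N1CCN([C@H]2C[C@@H](n3cc(-c4ccccc4O)c4c(N)ncnc43)C2)CC1` gives > 10000 nM, which is a limit of the assay and not a number. Compound 1 therefore has no exact potency from which to count a step.

Compound 2 `COC(=O)N[C@H]1CC[C@@H](n2cc(-c3ccc(Cl)c(N)c3)c3c(N)ncnc32)CC1` gives 4600 nM and compound 3 `COC(=O)NC12CCC(n3cc(-c4cc(N)c(Cl)cc4F)c4c(N)ncnc43)(CC1)CC2` gives 4100 nM, two values within the scatter of each other. Both compounds differ from compound 1 in more than one place, so neither shows the effect of a single change.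

Compound 4 `CC(=O)N1CCN([C@H]2C[C@@H](n3cc(-c4cccc(O)c4)c4c(N)ncnc43)C2)CC1` keeps everything in compound 1 except the aryl group: 3-hydroxyphenyl in place of 2-hydroxyphenyl on an aromatic carbon. In words, 3-hydroxyphenyl stands in place of 2-hydroxyphenyl on an aromatic carbon of the five-membered aromatic ring, and the two compounds have the same atoms, joined differently.

Among the compounds with values here, no measured pair isolates this change, so the expectation is only loosely anchored, by compound 2 at 4600 nM and compound 3 at 4100 nM. A modest move towards a stronger inhibitor is expected, and compound 4 may yet remain at the limit. The expected size of the change is an at least 1.6-fold lower number from compound 1 to compound 4 (0.22 log units; that floor lies within the scatter). For compound 4 the estimated value is 6000 nM, with an expected range from 1500 nM to 10000 nM.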

Compound 4, half-maximal inhibitory concentration: > 10000 nM
Compound 4: only a limit was reported; the forecaster's own chance of this, stated with the estimate: 40%; at least 1.6-fold (0.22 log units) between middle value and limit.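

In this assay compound 4 gives > 10000 nM as a limit of the assay and not a number. No step can be read from compound 1 to compound 4, because both stand at a limit: the limit of > 10000 nM in this assay, at which 2 of the 4 values shown sit. The compounds shown leave open whether 3-hydroxyphenyl and 2-hydroxyphenyl on the shared core differ at all in this assay.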